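Fluorine on the thioaryl ring across two cores

This account rests on a few compounds, and the source may have more. Where it says the series, first, only, none or still open, it means among the compounds named here.

Measured compounds:
- compound 1, `c1ccc(Sc2ncnc3[nH]cnc23)cc1`: 33%
- compound 2, `Fc1ccc(Sc2ncnc3[nH]cnc23)cc1`: 37%
- compound 3, `Cn1c(-c2ccc(S(C)(=O)=O)cc2)nc2c(Sc3ccccc3)ncnc21`: 5%

All three were tested in an assay on isolated protein for inhibition of Rho-associated protein kinase 1 (Homo sapiens), tested at 30 uM; a higher number here means more inhibition at the concentration tested (going by the name of the read-out), a lower number less inhibition. Compound 1 and compound 2 share one core and differ by a single change, (fluoro in place of hydrogen on an aromatic carbon). That change gave a number 4 percentage points higher from compound 1 to compound 2 (within the scatter), so on this core the two values cannot be told apart.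

Compound 3 carries a second, larger core, and the difference between the two cores is not broken down here. In this assay compound 3 gives 5%, the lowest of the three numbers; the gap to compound 1 and to compound 2 lies beyond the scatter in both cases.

Compound 4, `Cn1c(-c2ccc(S(C)(=O)=O)cc2)nc2c(Sc3ccc(F)cc3)ncnc21`, is not yet measured. It stands to compound 3 as compound 2 stands to compound 1: the change is fluoro in place of hydrogen on an aromatic carbon, and the place of the change is the same in both pairs. Going by the values given here, the only measured instance of this change, from compound 1 to compound 2, stayed within the scatter. Carrying that over, compound 4 is expected to sit close to compound 3, with an estimated step of a number 3 percentage points higher from compound 3 to compound 4 (within the scatter) in this assay, resting on the step from compound 1 to compound 2 and on the value of compound 3. The estimate for compound 4 in this assay is 8%, with a likely range from 0% to 20%.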

Compound 4, a percentage reported as inhibition, at one concentration (the size of the read-out at that concentration, not a potency): 0%
Beside the measured number, compound 4's estimate is 8 percentage points above it; low and high end bracket the measured number.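

In this assay, phenylsulfanyl to (4-fluorophenyl)sulfanyl gives a number 5 percentage points lower from compound 3 to compound 4 (within the scatter), so on the core of compound 3, as on the core of compound 1, the change yields no readable step, and the two cores agree: the same change on two cores in this assay, a number 4 percentage points higher (within the scatter) from compound 1 to compound 2 and a number 5 percentage points lower (within the scatter) from compound 3 to compound 4, 9 percentage points apart, within the scatter of two such steps.
The opposite signs of the two steps carry no weight at this scatter, so in these two pairs the change carries over from one core to the other as a step too small to read. Going by these compounds alone, this does not show that fluoro is without any effect, since the comparison rests on only two pairs at a single concentration in one assay, and compound 3 at 5% and compound 4 at 0% stand so near the bottom of the read-out that little room remains for a further fall on this core.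

Open, as far as these compounds go, is whether another group on the same ring in place of hydrogen, such as chloro, methoxy or an amine, would move the number beyond the scatter on either core. Also open, from the compounds shown here alone, is how the number responds when the methylsulfonyl group of compound 3 gives way to a carboxylic acid or an amide.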